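Chloro Added to the Anilino Ring of Chalcone Thiazoles

The compounds below may be only part of what the source reports. "The series", "measured", "known", "first", "only" and "open" are said of these compounds alone.

Measured so far:
Compound 1, `COc1cccc(/C=C/C(=O)c2sc(Nc3ccc(Cl)cc3)nc2C)c1` — > 25000 nM in a functional assay on Bel-7402 cells (Homo sapiens) for cytotoxicity, read by MTT assay; on this read-out higher numbers stand for weaker inhibition and lower numbers for stronger inhibition
Compound 2, `COc1cccc(/C=C/C(=O)c2sc(Nc3ccccc3)nc2C)c1` — > 25000 nM
Compound 3, `COc1cc(/C=C/C(=O)c2sc(Nc3cccc(Cl)c3)nc2C)cc(OC)c1OC` — 14000 nM

In this assay compound 1 gives only a limit, not a number. Compound 2 likewise gives only a limit. Among the measured compounds shown here, compound 3 is the one compound with a true number here; it stands as the limit of > 25000 nM in this assay, at which 2 of the 3 values shown sit, shows, with the other two values sitting at a limit. The difference between the core of compound 2 and the core of compound 3 is not broken down here.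

Between compound 2 and compound 1 the change is chloro in place of hydrogen on an aromatic carbon, and the step it made is a step that the two limits leave unreadable from compound 2 to compound 1, so its size cannot be read.

Compound 4, `COc1cc(/C=C/C(=O)c2sc(Nc3ccc(Cl)c(Cl)c3)nc2C)cc(OC)c1OC`, has not yet been measured. It arises from compound 3 by chloro in place of hydrogen on an aromatic carbon. This is the same kind of change as that from compound 2 to compound 1, but the place differs: here the entering chloro sits ortho to a chloro group, which was not so before. Because the measured step that the two limits leave unreadable from compound 2 to compound 1 is unreadable, the expected step of a 1.6-fold lower number from compound 3 to compound 4 (0.19 log units; within the scatter) rests only on compound 3 at 14000 nM and is taken as small. Compound 4 is therefore estimated at 9000 nM, expected between 3000 nM and 25000 nM.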

Compound 4, half-maximal inhibitory concentration: > 25000 nM
Compound 4 ended at the assay's limit; the forecaster's own chance of this, stated with the estimate: 25%; at least 2.7-fold (0.44 log units) between middle value and limit.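

In this assay, adding the chloro to the core of compound 3 gave an at least 1.7-fold higher number from compound 3 to compound 4 (0.25 log units; that floor lies within the scatter), so the change brought no gain in inhibition on this core, although that floor alone does not establish a real loss. Compound 4 gives > 25000 nM, which is a limit of the assay and not a number. The step for the same change on the other core, from compound 2 to compound 1, cannot be read, so the data do not show whether the change carries from one core to the other, and most of the series rests at one mark: the limit of > 25000 nM in this assay, at which 3 of the 4 values shown sit.

The compounds shown leave open whether an amine or a carboxylic acid, entering at the place the chloro took in compound 4, would give a different result on the core of compound 3. Also open, going by these compounds, is the true strength of compound 1, compound 2 and compound 4 in this assay, since each of these is known only as a limit.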